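A few compounds are considered here, and "the series" means these few. Any claim that something is new, unique, unknown or untested is made for them only; others in the source may bear on it.

Working notes, adenosine A3 series. In an assay on CHO cells for displacement of a labelled ligand from adenosine receptor A3 (Homo sapiens), read by scintillation counting, tested at 10 uM (a lower number here means less inhibition, a higher number more inhibition at the concentration tested (going by the name of the read-out)), compound 1 `Cc1sc(N)c(C(=O)c2ccc(Cl)cc2)c1-c1ccccc1` gives 1%, compound 2 `CC(C)(C)Cc1c(-c2ccccn2)sc(N)c1C(=O)c1ccc(Cl)cc1` gives 1% and compound 3 `CC(C)(C)Cc1c(-c2ccc(F)cc2)sc(N)c1C(=O)c1ccc(Cl)cc1` gives 9%. Compound 3 sits at the top of the three numbers, yet its gaps to compound 1 and to compound 2 both lie within the scatter, so all three numbers read as level and low at this concentration. Compound 4 `CC(C)(C)Cc1c(-c2ccc(Cl)cc2)sc(N)c1C(=O)c1ccc(Cl)cc1` carries the change (chloro in place of fluoro on an aromatic carbon). For the measured compounds named here, the only measured step, a number 8 percentage points higher from compound 2 to compound 3 (within the scatter), concerns a different position and was itself within the scatter; no measured step touches the halogen that is swapped here. Compound 4 is therefore expected to stay near compound 3, a step of a number 1 percentage points higher from compound 3 to compound 4 (within the scatter) in this assay. Compound 4 is estimated at 10%, range 0% to 25%.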

Compound 4, a percentage reported as inhibition, at one concentration (the size of the read-out at that concentration, not a potency): 1%
Compound 4: the middle estimate sits 9 percentage points above what was measured; measured number inside the range.
By their numbers in this assay, from the lowest: compounds 1, 2, 4 and 3 (each within the scatter of the next).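

Chloro in place of fluoro on the aromatic carbon para to a large group gives a number 8 percentage points lower from compound 3 to compound 4 (within the scatter) in this assay and is the first step read at this halogen. Set against pyridin-2-yl, 4-chlorophenyl gives no change at the digits printed from compound 2 to compound 4 (within the scatter) and so adds a second step at this ring position, leaving 4-fluorophenyl, 4-chlorophenyl and pyridin-2-yl level at this concentration. No evidence bears on this flat result. Still open, from the compounds shown here alone, is whether an amine or a carboxylic acid in place of the halogen would give a number clear of the scatter.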